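A few compounds are considered here, and "the series" means these few. Any claim that something is new, unique, unknown or untested is made for them only; others in the source may bear on it.

Working notes on the series in a functional assay on SK-MEL-28 cells (Homo sapiens) for inhibition, read by MTT assay, with a stated time of 72 h; on this read-out higher numbers stand for weaker inhibition of growth and lower numbers for stronger inhibition of growth. Compound 3 `CC(=O)/C=C/C1=CC[C@H]2C(C)(C)CCC[C@]2(C)[C@H]1C=O` gives 28000 nM. Compound 1 `COC(=O)/C=C/C1=CC[C@H]2C(C)(C)CCC[C@]2(C)[C@H]1C=O` gives 27000 nM and compound 2 `COC(=O)/C=C/C=C/C1=CC[C@H]2C(C)(C)CCC[C@]2(C)[C@H]1C=O` gives 25000 nM. All three values lie within the scatter of one another, so compound 3 cannot be ranked against the other two.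

The next structure is compound 4 `C#CCCCOC(=O)/C=C/C1=CC[C@H]2C(C)(C)CCC[C@]2(C)[C@H]1C=O`, and the change is (pent-4-yn-1-yl)oxy in place of methyl on a carbonyl carbon. The closest measured step, a 1.0-fold higher number from compound 1 to compound 3 (0.02 log units; within the scatter), is an exchange on a carbonyl carbon of the same kind, methyl in place of methoxy, and it stays within the scatter. The two steps that alter the chain, a 1.1-fold lower number from compound 1 to compound 2 (0.03 log units; within the scatter) and a 1.1-fold higher number from compound 2 to compound 3 (0.05 log units; within the scatter), also stay within the scatter. None of the three measured compounds carries a triple bond or a group as large as the one entering, so these steps give only limited guidance and the range has to stay wide.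

No shift beyond the scatter is expected in this assay, and the expected step is a 1.3-fold lower number from compound 3 to compound 4 (0.10 log units; within the scatter). The estimate for compound 4 is 22000 nM, with an expected range of 9000 nM to 45000 nM.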

Compound 4, concentration for 50% growth inhibition: 36000 nM
Estimate against measurement, compound 4: 1.6-fold (0.21 log units) below; the range from low to high includes it.
By their numbers in this assay, from the lowest: compounds 2, 1, 3 and 4 (each within the scatter of the next).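

In this assay, (pent-4-yn-1-yl)oxy in place of methyl on a carbonyl carbon gives a 1.3-fold higher number from compound 3 to compound 4 (0.11 log units; within the scatter), and but-3-yn-1-yl in place of hydrogen on a saturated chain carbon bound to an oxygen next to a carbonyl group gives a 1.3-fold higher number from compound 1 to compound 4 (0.12 log units; within the scatter); the earlier exchange at this kind of carbon involved only methyl and methoxy, whereas these steps show that a far larger entering group with a triple bond also leaves the number within the scatter. The remaining comparison, a 1.4-fold higher number from compound 2 to compound 4 (0.16 log units; within the scatter), is also within the scatter, so the four compounds still cannot be ranked and neither the chain changes nor the exchanges on the carbonyl carbon separate them in this assay. No measurement is available that bears on the reason for this flat result.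

From the compounds shown here alone, whether a carboxylic acid, an amide or a longer chain ending in an amine on this carbonyl carbon would produce a shift beyond the scatter remains open. Going by these compounds, all four compounds also retain the aldehyde on the shared core, so the effect of replacing it with a hydroxymethyl or a carboxylic acid is unknown from these data.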